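The source may hold more compounds than are shown below. What is called first, only, known or untested is meant among the compounds shown, and "the series" means these compounds.

Measured compounds:
- compound 1 `CC(C)(C)c1ccc(/C=C/C(=O)c2ccc(OCC(=O)N[C@H]3CCOC3=O)cc2)cc1`: 6570 nM
- compound 2 `O=C(CNc1cccc(Cl)c1)N[C@H]1CCOC1=O`: > 64000 nM
- compound 3 `O=C(CNc1ccc(F)cc1)N[C@H]1CCOC1=O`: > 64000 nM

In a functional assay on DU-145 cells (Homo sapiens) for antiproliferative activity, read by MTT assay, with a stated time of 72 h (on this read-out higher numbers stand for weaker inhibition and lower numbers for stronger inhibition), compound 1 gives 6570 nM. For compound 2 the entry of > 64000 nM is a limit of this assay, not a number. For compound 3 the entry of > 64000 nM is likewise a limit, not a number. Among the compounds with values here, the pattern of the set is therefore (the limit of > 64000 nM in this assay, at which 2 of the 3 values shown sit), so compound 1 stands as the only compound with a measured number, and nothing beyond its own value can be read from the other two.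

Compound 4 `O=C(COc1ccc(C(=O)/C=C/c2cccc(Cl)c2)cc1)N[C@H]1CCOC1=O` is not yet measured in this assay. It departs from compound 1 in one place: 3-chlorophenyl in place of 4-(tert-butyl)phenyl on a double-bonded chain carbon bound to a double-bonded chain carbon. Within the data shown here, no measured pair in the set shows this change, so its size is not known from the data. The expectation is a modest step toward weaker inhibition, possibly within the scatter, from compound 1 to compound 4, as a 1.8-fold higher number from compound 1 to compound 4 (0.26 log units; within the scatter). Compound 4 is thus estimated at 12000 nM, with a range from 4000 nM to 40000 nM.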

Compound 4, half-maximal inhibitory concentration: 3700 nM
Compound 4: middle estimate off by 3.2-fold (0.51 log units), on the high side; measured number outside the range, below it.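

In this assay, placing 3-chlorophenyl in place of 4-(tert-butyl)phenyl on a double-bonded chain carbon bound to a double-bonded chain carbon gives a 1.8-fold lower number from compound 1 to compound 4 (0.25 log units; within the scatter). With only compound 1 as a measured number, the series could not show whether activity needed the 4-(tert-butyl)phenyl group; compound 4 shows that a 3-chlorophenyl group can stand where the 4-(tert-butyl)phenyl group stood, with the step remaining within the scatter. No measurement shown gives a cause for this step.

From the compounds shown here alone, the reading rests on a single pair, so how far this position extends beyond these two substituted phenyl groups stays open. A 4-chlorophenyl group would test the place of the chlorine, and a dimethylaminophenyl group would test an amine at this position.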